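The source may report more compounds than this note shows. Statements on the series, on what has been measured and on what is new or still open speak of the compounds shown alone.

- Compound 1 `C=C[C@@](C)(/C=C/c1ccc(O)cc1)CCC=O`: > 26000 nM (a limit)
- Compound 2 `C=C[C@@](C)(/C=C/c1ccc(O)cc1)CC/C=C/C(=O)OCC`: > 26000 nM (a limit)

In a functional assay on Raji cells (Homo sapiens) for cytotoxicity, with a stated time of 72 h (a lower number here means that less compound is needed, a higher number that more compound is needed for the effect), compound 2 gives > 26000 nM, which is a limit of the assay and not a number. The whole picture so far is the limit of > 26000 nM in this assay, at which 2 of the 2 values shown sit.

Compound 3 `C=C[C@@](C)(/C=C/c1ccc(O)cc1)CC/C=C/C(=O)OCc1ccccc1` differs from compound 2 in one place: phenyl in place of methyl on a saturated chain carbon bound to an oxygen next to a carbonyl group. Seen one bond further out, ethoxy becomes benzyloxy.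

Going by the values given here, the only measured step is a step that the two limits leave unreadable from compound 1 to compound 2, so it offers no size to carry over, and no step beyond the scatter is expected in this assay, in either direction. The expected change is an at least 1.1-fold lower number from compound 2 to compound 3 (0.07 log units; that floor lies within the scatter). Most likely the assay again reports only a limit. If a number appears, compound 3 is estimated at 22000 nM, with an expected range from 8000 nM to 50000 nM.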

Compound 3, half-maximal effective concentration: > 26000 nM
Compound 3 gave a limit, no number (the forecaster's own chance of this, stated with the estimate: 70%); middle value at least 1.1-fold (0.07 log units) away from the limit.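

Compound 3 also gives > 26000 nM in this assay, which is a limit and not a number. With compound 2 at a limit as well, the step between them cannot be read. The compounds shown leave open what their actual numbers are, and so whether phenyl in place of methyl changes anything, as all share one result: the limit of > 26000 nM in this assay, at which 3 of the 3 values shown sit.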